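A few compounds are considered here, and "the series" means these few. Any claim that something is new, unique, unknown or untested is made for them only; others in the source may bear on it.

In a functional assay on HepG2 cells (Homo sapiens) for cytotoxicity, read by MTT assay, with a stated time of 72 h (on this read-out higher numbers stand for weaker inhibition and lower numbers for stronger inhibition), compound 1 `CC(=C\c1ccccc1)/C=C1\CCC=CC1=O` gives 4600 nM and compound 3 `O=C1C=CCC/C1=C\C=C\c1ccc(F)cc1` gives 2900 nM and these two values lie within the usual scatter of each other. Compound 2 `O=C1C=CCC/C1=C\C(Br)=C\c1ccccc1` reports > 10000 nM as a limit of the assay, not a number. Compound 3 therefore sits level with compound 1 among the two true numbers available.

Compound 4 `O=C1C=CCC/C1=C\C=C\c1ccc(Br)cc1` differs from compound 3 by one change (bromo in place of fluoro on an aromatic carbon): bromo in place of fluoro on an aromatic carbon, para to a large group. Among the compounds with values here, the one measured step of an at least 2.1-fold higher number from compound 1 to compound 2 (0.33 log units; beyond the scatter) also brings in a bromo, but in place of methyl on a double-bonded chain carbon, so it offers only a weak guide to a change on an aromatic carbon. Within the data shown here, no measured step alters a group on the aromatic ring, so the data give no firm direction. The expected 1.1-fold higher number from compound 3 to compound 4 (0.04 log units; within the scatter) therefore stays within the scatter. The estimate for compound 4 is 3200 nM within an expected range of 1300 nM to 8000 nM on the same read-out.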

Compound 4, half-maximal inhibitory concentration: 6100 nM
For compound 4 the middle estimate is 1.9-fold (0.28 log units) below the measured one; the measured number falls inside the stated range.
By their numbers in this assay, from the lowest: compounds 3, 1 and 4 (each within the scatter of the next, the first and the last beyond it). At a limit, above all of these: compound 2.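

Within the data shown here, compound 3 and compound 4 give the first measured comparison of two groups on the aromatic ring, and the group on this carbon, para to a large group, matters in this assay: the change shows a 2.1-fold higher number from compound 3 to compound 4 (0.32 log units; beyond the scatter). Replacing fluoro with bromo swaps one heavy atom for one heavy atom and adds no hydrogen-bond donor, acceptor or charge, yet the number moves modestly toward weaker inhibition. Nothing measured here gives a reason for this step.

Two groups at one ring carbon make a single comparison, not a series. Where a chloro, a methoxy or an amine at this place would fall remains open, as does whether swapping fluoro for bromo elsewhere on the ring would give a step of similar size.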